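This account rests on a few compounds, and the source may have more. Where it says the series, first, only, none or still open, it means among the compounds named here.

Measured so far in a functional assay on MCF7 cells (Homo sapiens) for antiproliferative activity, read by MTT assay, with a stated time of 48 h; a lower number here means a stronger inhibitor, a higher number a weaker inhibitor:
Compound 1 `COc1ccc(C(=O)c2ccc3c(c2)C=CC(C)(C)O3)c(NC(=O)CBr)c1` gives 2880 nM
Compound 2 `COc1ccc(C(=O)c2ccc(OC)c3c2OC(C)(C)C=C3)c(NC(=O)CO)c1` gives 320 nM
Compound 3 `COc1ccc(C(=O)c2ccc(OC)c3c2C=CC(C)(C)O3)c(NC(=O)CN)c1` gives 1250 nM

Compound 2, at 320 nM in this assay, holds the lowest of the three numbers and is the strongest inhibitor among them. Its gaps to both others lie beyond the scatter, with compound 3 the nearest and compound 1 the furthest.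

The unmeasured compound 4 `CNCC(=O)Nc1cc(OC)ccc1C(=O)c1ccc(OC)c2c1OC(C)(C)C=C2` departs from compound 2 in one place, (methylamino in place of hydroxy on a saturated chain carbon bound to a carbonyl carbon), with methylamino in place of hydroxy on a saturated chain carbon bound to a carbonyl carbon. Among the compounds with values here, no measured pair isolates this change, so its size can only be judged loosely. Within the data shown here, the one measured compound with an amino group on that chain, compound 3, reads 1250 nM, a higher number than that of compound 2. A weaker result is therefore expected, modestly beyond the scatter, and the estimated step is a 2.5-fold higher number from compound 2 to compound 4 (0.40 log units; beyond the scatter). For compound 4 the estimated value is 800 nM, with an expected range of 250 nM to 2500 nM.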

Compound 4, half-maximal inhibitory concentration: 820 nM
The estimate for compound 4 lay 1.0-fold (0.01 log units) below the measured number, and the stated range covers the measured number.
By their numbers in this assay, from the lowest: compound 2; then compounds 4 and 3 (each within the scatter of the next); then compound 1.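

In this assay, within the data shown here, methylamino in place of hydroxy on a saturated chain carbon bound to a carbonyl carbon gives a 2.6-fold higher number from compound 2 to compound 4 (0.41 log units; beyond the scatter) and provides the first step in which a single change can be read directly. At this position on the core of compound 2, hydroxy therefore gives the stronger inhibitor of the two groups, while methylamino costs only a modest amount of activity. The data offer no explanation for this step.

The compounds shown do not separate the contribution of the nitrogen from that of its added methyl carbon, since no amino group is paired with hydroxy on this same core. From the compounds shown here alone, it also remains open how a dimethylamino group, a carboxylic acid or a longer chain would read at this place.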